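Swapping the carbonyl substituent of a compound at the limit

The compounds below may be only part of what the source reports. "The series", "measured", "known", "first", "only" and "open" are said of these compounds alone.

Measured in a functional assay on MCF7 cells (Homo sapiens) for antiproliferative activity, read by MTT assay, with a stated time of 48 h; a higher number here means a weaker inhibitor, a lower number a stronger inhibitor:
- compound 1 `CCn1c(C(=O)NCCN(C)C)ccc1C(CC)(CC)c1ccc(OCCC(O)(CC)CC)c(C)c1` gives 430 nM
- compound 2 `C=CCN(C)C(=O)c1ccc(C(CC)(CC)c2ccc(OCCC(O)(CC)CC)c(C)c2)n1CC` gives > 50000 nM, a limit and not a number
- compound 3 `CCOc1ccc(NC(=O)c2ccc(C(CC)(CC)c3ccc(OCCC(O)(CC)CC)c(C)c3)n2CC)cc1` gives > 50000 nM, a limit and not a number

Compound 3 has no exact value and stands at the limit of > 50000 nM in this assay, at which 2 of the 3 values shown sit. The next compound, compound 4 `CCOC(=O)CN(C)C(=O)c1ccc(C(CC)(CC)c2ccc(OCCC(O)(CC)CC)c(C)c2)n1CC`, keeps the shared core and changes only the group on the carbonyl carbon: ((ethoxycarbonyl)methyl)(methyl)amino in place of (4-ethoxyphenyl)amino on a carbonyl carbon.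

For the measured compounds named here, two measured steps bear on this change. The first is an at least 110-fold higher number from compound 1 to compound 2 (2.06 log units; beyond the scatter), and the second is an at least 110-fold higher number from compound 1 to compound 3 (2.06 log units; beyond the scatter). Both are large and beyond the scatter, and both remove the 2-(dimethylamino)ethyl group. A third comparison, a step that the two limits leave unreadable from compound 2 to compound 3, gives no size to work from.

Compound 4 lacks that group too, so going by an at least 110-fold higher number from compound 1 to compound 2 (2.06 log units; beyond the scatter) it is expected to resemble compound 2 and compound 3 rather than compound 1. No step beyond the scatter, in either direction, is therefore expected in this assay, and the assay will quite likely report only a limit again. The expected step is a number no higher from compound 3 to compound 4 (the limit leaves the size open). For compound 4 the estimated value is 50000 nM, with an expected range from 12000 nM to 100000 nM.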

Compound 4, half-maximal inhibitory concentration: 3210 nM
The estimate for compound 4 lay 16-fold (1.19 log units) above the measured number; measured number outside the range, below it.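

In this assay, compound 4 shows that losing the 2-(dimethylamino)ethyl group does not by itself send a compound to the limit, which compound 2 and compound 3 alone might have suggested: there is an at least 15-fold lower number from compound 3 to compound 4 (1.19 log units; beyond the scatter), and also an at least 15-fold lower number from compound 2 to compound 4 (1.19 log units; beyond the scatter). The second step is the more telling one, since those two compounds share the methyl on the amide-type nitrogen and differ only by ethoxycarbonyl in place of vinyl on a saturated chain carbon, while compound 1 remains the strongest of the four, with a 7.5-fold higher number from compound 1 to compound 4 (0.87 log units; beyond the scatter). The two lower steps give only minimum sizes, and the step between compound 2 and compound 3 cannot be read, because those compounds carry limits and not numbers: the limit of > 50000 nM in this assay, at which 2 of the 4 values shown sit.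

Going by these compounds, whether the ethoxycarbonyl group itself matters, or any group other than vinyl at that chain carbon would do as well, stays open, and a carboxylic acid or an amine in its place would help to tell these apart. Also open, on these data alone, is whether the same order of compounds holds in cells other than MCF7.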